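The source may hold more compounds than are shown below. What is called first, only, known or untested is meant among the compounds shown, and "the series" means these compounds.

Of the compounds shown here, three built on one shared core have been measured in a functional assay on DLD-1 cells (Homo sapiens) for antiproliferative activity, read by CellTiter-Glo, with a stated time of 72 h; a lower number here means a stronger inhibitor, a higher number a weaker inhibitor. Compound 1 `CC1CCN(C2CCN(S(=O)(=O)c3cccc(-c4ccc(Cl)cc4)c3)CC2)CC1` gives 15 nM, compound 2 `CC1CCN(C2CCN(S(=O)(=O)c3ccc(C#N)cc3)CC2)CC1` gives 2800 nM, and compound 3 `CC1CCN(C2CCN(S(=O)(=O)c3ccc(Cl)cc3Cl)CC2)CC1` gives 1 nM, the lowest number of the three and well clear of both others. Compound 4 `CC1CCN(C2CCN(S(=O)(=O)c3cccc(N)c3)CC2)CC1` differs from compound 3 in one place: 3-aminophenyl in place of 2,4-dichlorophenyl on a sulfonyl sulfur. Among the compounds with values here, the one directly comparable step runs the other way, with a ring carrying a nitrile swapped for the dichlorinated ring: a 2800-fold lower number from compound 2 to compound 3 (3.45 log units; beyond the scatter), a very large gain. Moving away from 2,4-dichlorophenyl again is therefore expected to cost a great deal, about a 1500-fold higher number from compound 3 to compound 4 (3.18 log units; beyond the scatter). Compound 4 is estimated at 1500 nM, with a likely range from 200 nM to 10000 nM.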

Compound 4, half-maximal inhibitory concentration: 3400 nM
Estimate against measurement, compound 4: 2.3-fold (0.36 log units) below; the range from low to high includes it.
By their numbers in this assay, from the lowest: compound 3; then compound 1; then compounds 2 and 4 (each within the scatter of the next).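

Replacing 2,4-dichlorophenyl on the sulfonyl sulfur with 3-aminophenyl gives a 3400-fold higher number from compound 3 to compound 4 (3.53 log units; beyond the scatter), so this ring can be exchanged for one that costs nearly all of the activity. That cost does not separate the amino ring from the nitrile ring, with a 1.2-fold higher number from compound 2 to compound 4 (0.08 log units; within the scatter). Amino in place of 4-chlorophenyl on an aromatic carbon gives a 230-fold higher number from compound 1 to compound 4 (2.36 log units; beyond the scatter), and among these four compounds only the two carrying chlorine give low numbers.

Nothing measured here explains these differences. Also open, on these data alone, is whether a ring carrying methyl groups in place of the chlorines would keep the low number.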